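Acyl variation on the methylated amide of the shared core

This account rests on a few compounds, and the source may have more. Where it says the series, first, only, none or still open, it means among the compounds named here.

Measured compounds in a functional assay on KB cells (Homo sapiens) for antiproliferative activity, read by MTT assay, with a stated time of 72 h; a lower number here means a stronger inhibitor, a higher number a weaker inhibitor:
compound 1 `CC(=O)N(C)c1ccc2[nH]c(-c3n[nH]c4ccccc34)cc2n1` gives 10300 nM
compound 2 `CCC(=O)N(C)c1ccc2[nH]c(-c3n[nH]c4ccccc34)cc2n1` gives 9300 nM
compound 3 `CN(C(=O)C(C)(C)C)c1ccc2[nH]c(-c3n[nH]c4ccccc34)cc2n1` gives 8390 nM

Three compounds share one core and differ only in the acyl group on the methylated amide nitrogen. Compound 3 holds the lowest number of the three in this assay, but the steps that separate it from the others, a 1.2-fold lower number from compound 1 to compound 3 (0.09 log units; within the scatter) and a 1.1-fold lower number from compound 2 to compound 3 (0.04 log units; within the scatter), lie within the scatter, as does a 1.1-fold lower number from compound 1 to compound 2 (0.04 log units; within the scatter). The three values therefore read as one level; none of the three is set apart.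

Compound 4 `CN(C(=O)c1ccccc1)c1ccc2[nH]c(-c3n[nH]c4ccccc34)cc2n1` is the next member. It differs from compound 3 as follows: phenyl in place of tert-butyl on a carbonyl carbon. Within the data shown here, the measured steps all concern saturated acyl groups of growing size and none moved the number beyond the scatter; no measured step brings an aromatic ring into this position, so the closest guide is the flatness of the whole series. The expectation is a step from compound 3 to compound 4 of a 1.0-fold lower number from compound 3 to compound 4 (0.02 log units; within the scatter), that is no step beyond the scatter, in either direction. Compound 4 is estimated at 8000 nM, with a range from 3000 nM to 25000 nM.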

Compound 4, half-maximal inhibitory concentration: 8580 nM
Beside the measured number, compound 4's estimate is 1.1-fold (0.03 log units) below it; the measured number falls inside the stated range.
By their numbers in this assay, from the lowest: compounds 3, 4, 2 and 1 (each within the scatter of the next).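

Compound 1, compound 2 and compound 3 carry only saturated acyl groups on the carbonyl carbon, whereas compound 4 brings in phenyl, with one six-membered aromatic ring of carbon only, and this assay still shows no separation. The change gives a 1.0-fold higher number from compound 3 to compound 4 (0.01 log units; within the scatter) against tert-butyl and a 1.1-fold lower number from compound 2 to compound 4 (0.03 log units; within the scatter) against ethyl and a 1.2-fold lower number from compound 1 to compound 4 (0.08 log units; within the scatter) against methyl, so all four compounds now read as one level. Among these four compounds, then, neither a saturated group nor an aromatic ring on this carbonyl carbon sets a compound apart, and no information is available on what lies behind that level.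

The compounds shown leave open whether a benzoyl carrying a further group, such as an amine or a carboxylic acid on the phenyl ring, would move the number beyond the scatter. They also leave open whether a longer chain ending in an amine on the carbonyl carbon, or a different group in place of the methyl on the amide nitrogen, would break this level.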